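Triazole-linked terpenoid esters against DU-145 proliferation

This account rests on a few compounds, and the source may have more. Where it says the series, first, only, none or still open, it means among the compounds named here.

Measured so far:
compound 1, `C/C(=C\CC/C(C)=C/CC[C@@H]1[C@@]2(C)CCC(=O)C(C)(C)[C@H]2CC[C@@]1(C)O)CC/C=C(\C)C(=O)OCc1cn(C[C@@H]2O[C@H](n3ccc(=O)[nH]c3=O)[C@H]3OC(C)(C)O[C@H]32)nn1`, > 150000 nM
compound 2, `C/C(=C\CC/C(C)=C/CC[C@@H]1[C@@]2(C)CCC(=O)C(C)(C)[C@H]2CC[C@@]1(C)O)CC/C=C(\C)C(=O)OCc1cn(-c2ccc(Br)cc2)nn1`, > 150000 nM

Two compounds have been run in a functional assay on DU-145 cells (Homo sapiens) for antiproliferative activity, read by MTT assay, with a stated time of 48 h; on this read-out higher numbers stand for weaker inhibition and lower numbers for stronger inhibition. For compound 1 the value > 150000 nM is a limit of the assay, not a number. For compound 2 the value > 150000 nM is likewise a limit, not a number. Compound 2 thus stands at the limit of > 150000 nM in this assay, at which 2 of the 2 values shown sit, and nothing in the measured set separates it from compound 1.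

Compound 3, `COc1ccccc1-n1cc(COC(=O)/C(C)=C/CC/C(C)=C/CC/C(C)=C/CC[C@@H]2[C@@]3(C)CCC(=O)C(C)(C)[C@H]3CC[C@@]2(C)O)nn1`, awaits measurement in this assay. It differs from compound 2 in one place: 2-methoxyphenyl in place of 4-bromophenyl on an aromatic nitrogen. Among the measured compounds shown here, no step between measured compounds is available, so the size of this change cannot be read from the data. Because compound 2 sits at the limit of > 150000 nM in this assay, at which 2 of the 2 values shown sit, the step that the limit leaves unreadable from compound 2 to compound 3 is expected to be none beyond the scatter. Compound 3 is estimated at 200000 nM, within 80000 nM to 500000 nM, most likely returned as a limit rather than a number.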

Compound 3, half-maximal inhibitory concentration: > 150000 nM
Compound 3: no number, only a limit; the forecaster's own chance of this, stated with the estimate: 80%; the middle value is on the limit's open side.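

Compound 2 and compound 3 both return limits, not numbers, so no step between them can be read: the limit of > 150000 nM in this assay, at which 3 of the 3 values shown sit.

The compounds shown leave open whether any group on that aromatic nitrogen, or any change to the shared core, gives a number rather than a limit.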